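The compounds below may be only part of what the source reports. "The series", "measured", "known", "first", "only" and "open" are said of these compounds alone.

Measured in a functional assay on Umbilical vein for antagonist activity at B1 bradykinin receptor (Homo sapiens), using Schild analysis, with a stated time of 30 min; on this read-out higher numbers stand for higher potency (the scale is a negative logarithm) and lower numbers for lower potency: compound 1 `Cc1c(Cl)ccc(S(=O)(=O)N(C)CCOCC(=O)N(C)Cc2ccc(C3=NCCN3)cc2)c1Cl` gives 9.1; compound 2 `COc1cc(C)c(S(=O)(=O)N(C)CCOCC(=O)N2CCC(C(O)CN(C)C)CC2)c(C)c1` gives 7.4; compound 3 `COc1cc(C)c(S(=O)(=O)N(C)CCOCC(=O)N2CCN(CC3CCN(C)CC3)CC2)c(C)c1` gives 8.6.

Compound 1 has the highest of the three numbers in this assay; compound 3 is nearest, a gap beyond the scatter below it, and compound 2 is furthest, well below. Compound 4 `CN(Cc1ccc(C2=NCCN2)cc1)C(=O)COCCN(C)S(=O)(=O)c1c(Cl)cccc1Cl` is not yet measured. It differs from compound 1 in one place: 2,6-dichlorophenyl in place of 2,4-dichloro-3-methylphenyl on a sulfonyl sulfur. Going by the values given here, no measured pair shows this change, so nothing fixes its size or direction. A modest loss is expected, of size a number 0.50 log units lower from compound 1 to compound 4 (beyond the scatter), roughly at the edge of the scatter. For compound 4 in this assay the estimate is 8.6, with a range from 8 to 9.2.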

Compound 4, negative logarithm of the antagonist equilibrium constant: 8.5
Estimate against measurement, compound 4: 0.10 log units above; the measured number falls inside the stated range.
By their numbers in this assay, from the lowest: compound 2; then compounds 4 and 3 (each within the scatter of the next); then compound 1.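

In this assay, going by these compounds alone, 2,6-dichlorophenyl in place of 2,4-dichloro-3-methylphenyl on a sulfonyl sulfur gives a number 0.60 log units lower from compound 1 to compound 4 (beyond the scatter) as the first measured step at this position. The substituents on this phenyl ring therefore affect potency, though compound 4 still reaches 8.5 with the rest of compound 1 unchanged. No measurement on hand accounts for this loss.

Going by these compounds, the change removes the methyl and alters the chlorine pattern together, so the share of each stays open. On these data alone, how an amine or a carboxylic acid on this phenyl ring would read also stays open.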